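Trimethoxybenzophenone cinnamamides: trimming the cinnamoyl ring

The source may report more compounds than this note shows. Statements on the series, on what has been measured and on what is new or still open speak of the compounds shown alone.

Measured so far:
compound 1 `COc1cc(C(=O)c2cc(OC)c(OC)c(OC)c2)cc(NC(=O)/C=C/c2cc(OC)c(OC)c(OC)c2)c1OC` — 2500 nM
compound 2 `COc1ccc(/C=C/C(=O)Nc2cc(C(=O)c3cc(OC)c(OC)c(OC)c3)cc(OC)c2OC)cc1OC` — 1300 nM

For the measured compounds named here, in a functional assay on B16 cells (Mus musculus) for cytotoxicity, read by MTT assay, with a stated time of 72 h (on this read-out lower numbers stand for stronger inhibition and higher numbers for weaker inhibition), compound 2 gives the lower of the two numbers recorded; its only neighbour is compound 1, and the step of a 1.9-fold lower number from compound 1 to compound 2 (0.28 log units; within the scatter) does not reach beyond the scatter. Compound 3 `COc1ccc(/C=C/C(=O)Nc2cc(C(=O)c3cc(OC)c(OC)c(OC)c3)cc(OC)c2OC)cc1` takes the same kind of change one stage further: hydrogen in place of methoxy on an aromatic carbon, so that the 2-(3,4-dimethoxyphenyl)ethenyl unit of compound 2 becomes a 2-(4-methoxyphenyl)ethenyl unit. Going by the values given here, the only step that bears on it is the methoxy removal on the same ring, from compound 1 to compound 2, which stayed within the scatter. On that basis no shift beyond the scatter is expected in this assay for compound 3, and the estimated step is a 1.2-fold higher number from compound 2 to compound 3 (0.06 log units; within the scatter). Compound 3 is therefore expected to give about 1500 nM, with a plausible range from 600 nM to 4000 nM.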

Compound 3, half-maximal inhibitory concentration: 9400 nM
Estimate against measurement, compound 3: 6.3-fold (0.80 log units) below; the measured number lies above the stated range.
By their numbers in this assay, from the lowest: compounds 2 and 1 (each within the scatter of the next); then compound 3.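

In this assay the change from 3,4-dimethoxyphenyl to 4-methoxyphenyl gives a 7.2-fold higher number from compound 2 to compound 3 (0.86 log units; beyond the scatter) and so reaches beyond the scatter, whereas the earlier methoxy removal on this ring, a 1.9-fold lower number from compound 1 to compound 2 (0.28 log units; within the scatter), did not. Hydrogen in place of methoxy on this ring therefore does not act alike at every carbon, and the carbon changed in compound 3 is the one of the two where the number moves beyond the scatter. Over both removals together, 4-methoxyphenyl in place of 3,4,5-trimethoxyphenyl gives a 3.8-fold higher number from compound 1 to compound 3 (0.58 log units; beyond the scatter) as the net result. Nothing measured here accounts for this loss.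

Open, on these data alone, is whether a group other than methoxy, such as hydroxyl or an amine, could stand on that carbon without the same rise. Also open, as far as these compounds go, is what an unsubstituted phenyl on the same core would give in this assay for comparison.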